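The source may hold more compounds than are shown below. What is called first, only, known or untested is meant among the compounds shown, and "the series" means these compounds.

These compounds were tested in a functional assay on CCRF-CEM cells (Homo sapiens) for cytotoxicity, read by MTT assay, with a stated time of 72 h; a higher number here means a weaker inhibitor of growth, a lower number a stronger inhibitor of growth. Compound 1, `COc1ccc(CNc2nc([Se]C)nc3ccccc23)cc1`, gives in this assay only a limit, > 100000 nM. Compound 2, `COc1ccc(CNc2nc([SeH])nc3ccccc23)cc1`, likewise gives in this assay only a limit, > 100000 nM. The change from compound 1 to compound 2 is hydrogen in place of methyl on a selenium, and its effect, a step that the two limits leave unreadable from compound 1 to compound 2, cannot be read, since both values are limits. Compound 3, `CCCCC[Se]c1nc([Se]CCCCC)c2ccccc2n1`, which differs from the other two in several places, gives in this assay 65700 nM. Across the whole set, (the limit of > 100000 nM in this assay, at which 2 of the 3 values shown sit), so there is little to read.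

Compound 4, `CSc1ccc(CNc2nc([SeH])nc3ccccc23)cc1`, is the compound not yet measured. It differs from compound 2 by methylsulfanyl in place of methoxy on an aromatic carbon. Among the compounds with values here, the only measured step that bears on this pair is the one from compound 1 to compound 2, and that one is unreadable; no measured step involves the methoxy group itself. Nothing in the data therefore points to a change beyond the scatter, and the most likely outcome is that compound 4 again reaches only a limit. Compound 4 is estimated at 150000 nM, with a range from 40000 nM to 600000 nM. This corresponds to an expected step that the limit leaves unreadable from compound 2 to compound 4, within the scatter.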

Compound 4, concentration for 50% growth inhibition: 71900 nM
Compound 4: the middle estimate sits 2.1-fold (0.32 log units) above what was measured, and the stated range covers the measured number.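

In this assay, within the data shown here, compound 4 gives 71900 nM, so with methylsulfanyl on this ring the series yields a readable number for the first time among the compounds that share the substituted benzyl amine side chain. Putting methylsulfanyl in place of methoxy, on the aromatic carbon para to a large group, exchanges an oxygen for a sulfur and gives an at least 1.3-fold lower number from compound 2 to compound 4 (0.14 log units; that floor lies within the scatter), so this position can at least be read, although that floor alone does not prove a real change. The true size of the step stays unknown because compound 2 is held at a limit, not a number: the limit of > 100000 nM in this assay, at which 2 of the 4 values shown sit.

On these data alone, the step from compound 1 to compound 2 cannot be read either, so it remains open whether a methyl on the selenium would matter once methylsulfanyl is in place. The compounds shown also leave open how other groups at this position would behave, such as a longer ethylsulfanyl chain, a chlorine atom or an amine, and whether any of them would give a number clearly beyond the scatter.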